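This account rests on a few compounds, and the source may have more. Where it says the series, first, only, none or still open, it means among the compounds named here.

Measured so far:
Compound 1, `COc1ccc(-n2nc(-c3ccccc3)nc2CNc2ccc(C(=O)NO)cc2)cc1`: 7050 nM
Compound 2, `COc1ccc(-c2nc(CNc3ccc(C(=O)NO)cc3)n(-c3ccccc3)n2)cc1`: > 20000 nM

Of the compounds shown here, two have been tested in a functional assay on MGC-803 cells (Homo sapiens) for antiproliferative activity, read by MTT assay, with a stated time of 72 h; a lower number here means a stronger inhibitor, a higher number a weaker inhibitor. Compound 1 gives 7050 nM in this assay. For compound 2 the result is recorded only as a limit, > 20000 nM, so compound 2 stands at the limit of > 20000 nM in this assay, at which 1 of the 2 values shown sits, and no exact number is known for it. Compound 3, `O=C(NO)c1ccc(NCc2nc(-c3ccccc3)nn2-c2ccccc2)cc1`, is the compound still to be measured. The change from compound 2 to compound 3 is hydrogen in place of methoxy on an aromatic carbon. Going by the values given here, no pair of measured compounds differs in only one place, so there is no measured step to lean on. Losing a methoxy for a hydrogen is a small change, and no shift beyond the usual scatter is expected in this assay. Compound 3 is expected to stay weak, as compound 2 shows only the limit (the limit of > 20000 nM in this assay, at which 1 of the 2 values shown sits). The expected step is a step that the limit leaves unreadable from compound 2 to compound 3. Compound 3 is estimated at 25000 nM, in a range from 8000 nM to 80000 nM.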

Compound 3, half-maximal inhibitory concentration: 17700 nM
The estimate for compound 3 lay 1.4-fold (0.15 log units) above the measured number, and the stated range covers the measured number.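

In this assay, going by these compounds alone, replacing the 4-methoxyphenyl of compound 1 with phenyl gives a 2.5-fold higher number from compound 1 to compound 3 (0.40 log units; beyond the scatter), the only exact one-place step here, so at this place the methoxy goes with a modestly stronger result than hydrogen. The same swap, made on the other phenyl group, gives an at least 1.1-fold lower number from compound 2 to compound 3 (0.05 log units; that floor lies within the scatter). That step can only be read as a floor, and no size can be given for it, because compound 2 is recorded as a limit rather than a number: the limit of > 20000 nM in this assay, at which 1 of the 3 values shown sits.

Whether this gain is specific to methoxy stays open, since the compounds shown carry only methoxy or hydrogen at these places, and a fluorine, an amine or a longer ethoxy chain could tell more. The two methoxy places also cannot be ranked against each other from any one-place step.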